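This account rests on a few compounds, and the source may have more. Where it says the series, first, only, none or still open, it means among the compounds named here.

For the measured compounds named here, in an ADME assay on Vero 76 cells (Chlorocebus sabaeus) for cytotoxicity, read by MTT assay, with a stated time of 96 h (on this read-out lower numbers stand for higher toxicity in this test and higher numbers for lower toxicity in this test), compound 1 `Cc1ccccc1C1CC(c2ccc(OCc3ccccc3)cc2)=NN1c1ccc(S(N)(=O)=O)cc1` gives 100000 nM, the highest of the three numbers measured so far. Compound 2 `NS(=O)(=O)c1ccc(N2N=C(c3ccc(OCc4ccccc4)cc3)CC2c2ccccc2Cl)cc1`, which carries a chloro in place of a methyl on an aromatic carbon, gives 92000 nM; the step of a 1.1-fold lower number from compound 1 to compound 2 (0.04 log units; within the scatter) shows that this change left the read-out essentially where it was. Compound 3 `Cc1cccc(C2CC(c3ccccc3)=NN2c2ccc(S(N)(=O)=O)cc2)c1` gives 25000 nM, a clearly lower number than compound 1, but the two differ in more than one place, so no single change can be tied to that gap.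

Compound 4 `Cc1cccc(C2CC(c3ccc(OCc4ccccc4)cc3)=NN2c2ccc(S(N)(=O)=O)cc2)c1` differs from compound 1 in one place only: 3-methylphenyl in place of 2-methylphenyl on a saturated ring carbon. Going by the values given here, the only measured single-place step, from compound 1 to compound 2, also altered the substituent on this same aromatic ring and stayed within the scatter. Compound 3 also bears the 3-methylphenyl group, yet its other difference from compound 1 prevents any direct reading. On this basis, the change to compound 4 is expected to give no step beyond the scatter, so the expected step is no change at the digits printed from compound 1 to compound 4 (within the scatter). For compound 4 in this assay the estimate is 100000 nM, with a range from 50000 nM to 200000 nM.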

Compound 4, half-maximal cytotoxic concentration: 100000 nM
Estimate against measurement, compound 4: no gap at the digits printed; the range from low to high includes it.
By their numbers in this assay, from the lowest: compound 3; then compounds 2, 1 and 4 (each within the scatter of the next).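

In this assay the saturated ring carbon now carries three different aromatic groups that can be compared, and 3-methylphenyl in place of 2-methylphenyl gives no change at the digits printed from compound 1 to compound 4 (within the scatter) so moving the methyl around this ring leaves no visible mark on the read-out. Putting 3-methylphenyl in place of 2-chlorophenyl at the same carbon gives a 1.1-fold higher number from compound 2 to compound 4 (0.04 log units; within the scatter) so these three groups read alike at this position, at least with the rest of the molecule held constant. A step beyond the scatter appears only at a different place, where benzyloxy in place of hydrogen on an aromatic carbon gives a 4.0-fold higher number from compound 3 to compound 4 (0.60 log units; beyond the scatter) and this shows that, with 3-methylphenyl held fixed, adding benzyloxy goes with lower toxicity in this test.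

Going by these compounds, whether the read-out would stay this flat with a phenyl ring bearing an amine or a carboxylic acid at the saturated ring carbon remains open, as does whether benzyloxy would give a similar step alongside 2-methylphenyl or 2-chlorophenyl. Nothing available explains either the flat result at this position or the step seen with benzyloxy.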